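Fluoro Added Beside Ethyl Rather Than Trifluoroethoxy

This account rests on a few compounds, and the source may have more. Where it says the series, first, only, none or still open, it means among the compounds named here.

Of the compounds shown here, three of a shared core have been tested in an assay on mitochondria from L6 cells (Rattus norvegicus) for activation, with a stated time of 90 min; a higher number here means that more compound is needed for the effect, a lower number that less compound is needed. Compound 1, `Oc1nc2nonc2nc1Nc1ccc(OCC(F)(F)F)cc1`, gives 42300 nM. Compound 2, `Oc1nc2nonc2nc1Nc1ccc(OCC(F)(F)F)c(F)c1`, gives 10400 nM. Compound 3, `CCc1ccc(Nc2nc3nonc3nc2O)cc1`, gives 10700 nM; compound 2 and compound 3 lie within the scatter of each other.

Compound 2 differs from compound 1 in one place, (fluoro in place of hydrogen on an aromatic carbon), and the step was a 4.1-fold lower number from compound 1 to compound 2 (0.61 log units; beyond the scatter). Compound 3 differs from compound 1 in another place, (ethyl in place of 2,2,2-trifluoroethoxy on an aromatic carbon), with a step of a 4.0-fold lower number from compound 1 to compound 3 (0.60 log units; beyond the scatter).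

Compound 4, `CCc1ccc(Nc2nc3nonc3nc2O)c(F)c1`, has not yet been measured in this assay. It differs from compound 3 by fluoro in place of hydrogen on an aromatic carbon. This is the same kind of change as from compound 1 to compound 2, but not the same: there the entering fluoro was ortho to a 2,2,2-trifluoroethoxy group (6 heavy atoms) and meta to a large group, whereas here it is ortho to a large group and meta to an ethyl group (2 heavy atoms). Among the compounds shown, this kind of change occurs two times in all.

For the measured compounds named here, the expectation for compound 4 rests on the single earlier instance, where compound 2 gained on compound 1 by a 4.1-fold lower number from compound 1 to compound 2 (0.61 log units; beyond the scatter). Because that step was beyond the scatter, a step of a 3.1-fold lower number from compound 3 to compound 4 (0.49 log units; beyond the scatter) is estimated for compound 4, somewhat smaller, as the surroundings are not identical. Compound 4 is therefore expected near 3500 nM in this assay, with a plausible range from 1500 nM to 9000 nM.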

Compound 4, half-maximal effective concentration: 6700 nM
The estimate for compound 4 lay 1.9-fold (0.28 log units) below the measured number, and the stated range covers the measured number.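

With the ethyl group in place of 2,2,2-trifluoroethoxy, fluoro in place of hydrogen on the aromatic carbon gives a 1.6-fold lower number from compound 3 to compound 4 (0.20 log units; within the scatter) in this assay, a step that cannot be told apart from the ordinary spread of repeated measurements. Set beside the earlier instance of the same change, this step cannot be said to differ from it, since the gap between the two remains inside what two such steps can show: the same change on two cores in this assay, a 4.1-fold lower number (0.61 log units; beyond the scatter) from compound 1 to compound 2 and a 1.6-fold lower number (0.20 log units; within the scatter) from compound 3 to compound 4, 2.5-fold (0.41 log units) apart, within the scatter of two such steps. For the compounds shown here, the pair therefore gives no firm sign that the effect of the fluoro depends on the core carrying it, but it does not show that the effect carries over either, as only one of the two steps stands clear of the scatter and two instances cannot fix its size on a further core.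

The compounds shown leave open how the same change behaves with other groups in the place of the ethyl or 2,2,2-trifluoroethoxy group, such as a methoxy group, a longer alkyl chain or an amine. They also leave open whether chloro or methyl, entering at the same aromatic carbon in place of fluoro, would give a step of similar size in this assay.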